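Phenoxy for benzyl on the extended-chain amide

The source may report more compounds than this note shows. Statements on the series, on what has been measured and on what is new or still open speak of the compounds shown alone.

Compound 2 `O=C(CCCCCCCCn1cc(-c2cccnc2)nn1)Nc1ccccc1Cc1ccccc1` carries a benzyl on the aromatic carbon of the anilide and, in a functional assay on SH-SY5Y cells (Homo sapiens) for cytotoxicity, tested at 1 uM (a lower number here means a stronger effect, a higher number a weaker effect of the compound at the concentration tested), compound 2 gives 13.1%. Among the three measured compounds it sits second highest. Compound 1 `O=C(CCCCCCCCn1cc(-c2cccnc2)nn1)Nc1ccccc1-c1ccccc1` gives 13%, and the step of a number 0.1 percentage points higher from compound 1 to compound 2 (within the scatter) shows that benzyl in place of phenyl changed nothing that can be told from the scatter. Compound 3 `O=C(CCCCCCn1cc(-c2cccnc2)nn1)Nc1ccccc1Oc1ccccc1`, which has the phenoxy but a shorter chain, gives 24.7%, and that gap to compound 2 is beyond the scatter.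

Compound 4 `O=C(CCCCCCCCn1cc(-c2cccnc2)nn1)Nc1ccccc1Oc1ccccc1` differs from compound 2 by phenoxy in place of benzyl on an aromatic carbon.

Within the data shown here, no measured step shows phenoxy in place of benzyl directly. Among the measured compounds shown here, the one step, benzyl for phenyl, was within the scatter, so on that evidence alone no change would be expected. For the measured compounds named here, compound 3, however, is the only phenoxy compound measured, and its weaker read-out leaves open that the phenoxy, rather than the chain, sets that number; the data do not separate the two. Compound 4 is therefore expected to land between the two, with a step of a number 5.9 percentage points higher from compound 2 to compound 4 (within the scatter) expected. The estimate for compound 4 is 19%, with a range from 9% to 30%.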

Compound 4, a percentage reported as activity, at one concentration (the size of the read-out at that concentration, not a potency): 22.6%
Beside the measured number, compound 4's estimate is 3.6 percentage points below it; the measured number falls inside the stated range.
By their numbers in this assay, from the lowest: compounds 1, 2, 4 and 3 (each within the scatter of the next, the first and the last beyond it).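

Phenoxy in place of benzyl on an aromatic carbon, ortho to a large group, gives a number 9.5 percentage points higher from compound 2 to compound 4 (within the scatter) in this assay, while phenoxy in place of phenyl at the same carbon gives a number 9.6 percentage points higher from compound 1 to compound 4 (within the scatter) on the same chain. Among these compounds, with the chain of compound 1 held fixed, no single step among phenyl, benzyl and phenoxy is therefore beyond the scatter, even though phenoxy enters with one hydrogen-bond acceptor and benzyl and phenyl with none. Compound 4 and compound 3 differ only in chain length and stand within the scatter of each other, with compound 4 at 22.6% and compound 3 at 24.7% in this read-out, so with phenoxy held fixed the chain change also gives no difference that can be told from the scatter.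

Still open, as far as these compounds go, is whether a different group on this aromatic carbon, such as an amine or a carboxylic acid, or a longer chain than that of compound 4, would move the read-out beyond the scatter. Nothing available bears on the reason for these numbers.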